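Swapping the halogen pattern on a sulfur-linked phenyl ring

This account rests on a few compounds, and the source may have more. Where it says the series, first, only, none or still open, it means among the compounds named here.

Compound 1 `Nc1cc(N)c2nc(-c3ccccc3)c(Sc3ccc(F)cc3)nc2c1` and compound 2 `COc1cc(CNc2nc3cc(N)cc(N)c3nc2-c2ccccc2)cc(OC)c1OC` share one core and were both tested in a functional assay on M14 cells (Homo sapiens) for inhibition, read by sulforhodamine B assay, with a stated time of 48 h; a higher number here means a weaker inhibitor of growth, a lower number a stronger inhibitor of growth. In this assay compound 1 gives 30900 nM, while compound 2 gives 18200 nM; these two numbers lie within the usual scatter of repeated measurements, so neither can be called the stronger inhibitor of growth on this evidence. Compound 3 `Nc1cc(N)c2nc(-c3ccccc3)c(Sc3ccc(Cl)c(Cl)c3)nc2c1` has not yet been measured. It differs from compound 1 in one place: 3,4-dichlorophenyl in place of 4-fluorophenyl on a sulfur. For the measured compounds named here, no measured pair shows what such a change does in this assay, so any expectation rests on the structural change alone. The step of a 1.5-fold lower number from compound 1 to compound 3 (0.19 log units; within the scatter) is expected to stay small, and its direction is uncertain. Compound 3 is therefore estimated at 20000 nM in this assay, within a range from 6000 nM to 60000 nM.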

Compound 3, concentration for total growth inhibition: < 100000 nM
Compound 3: a limit, no number (the forecaster's own chance of this, stated with the estimate: 10%); the middle value does not contradict the limit.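

In this assay compound 3 gives < 100000 nM, which is a limit of the assay and not a number. The change from compound 1 to compound 3 therefore cannot be read as a step. The compounds shown leave open what 3,4-dichlorophenyl in place of 4-fluorophenyl on a sulfur does to the read-out.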